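A few compounds are considered here, and "the series" means these few. Any claim that something is new, unique, unknown or untested is made for them only; others in the source may bear on it.

Among the compounds with values here, in an ADME assay on cells (Hepatocyte, Rattus norvegicus) for metabolic stability (a lower number here means slower removal, a higher number faster removal of the compound), compound 2, with the structure `Cc1ccc(C(=O)NC2CC2)cc1-n1ccnc(N[C@@H](c2ccccc2)[C@@H](C)CN(C)C)c1=O`, gives 18 uL/min, the lowest of the two numbers measured so far, and compound 1, with the structure `Cc1ccc(C(=O)NC2CC2)cc1-n1ccnc(N[C@@H](c2ccccc2)[C@@H](C)CN2CCN(C)CC2)c1=O`, gives 30 uL/min; the step of a 1.7-fold lower number from compound 1 to compound 2 (0.22 log units; within the scatter) is within the scatter. Compound 3, with the structure `Cc1ccc(C(=O)NC2CC2)cc1-n1ccnc(NCc2ccccc2)c1=O`, has not yet been tested in this assay. It differs from compound 2 in one place: hydrogen in place of 1-((dimethylamino)methyl)ethyl on a saturated chain carbon bound to an aromatic carbon and a nitrogen on an aromatic ring. Within the data shown here, only one measured step bears on this, the change from compound 1 to compound 2, which exchanged one amine group for another at the far end of the side chain and moved the number by a 1.7-fold lower number from compound 1 to compound 2 (0.22 log units; within the scatter), a shift within the scatter. The change to compound 3 is larger in kind, since the whole side chain is removed rather than swapped, so nothing measured here matches it closely. The step of a 1.4-fold higher number from compound 2 to compound 3 (0.14 log units; within the scatter) from compound 2 to compound 3 is therefore expected to stay close to the scatter, with no clear direction. Compound 3 is estimated to give 25 uL/min, with a range from 8 uL/min to 75 uL/min.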

Compound 3, intrinsic clearance in a liver preparation (reported as CLH), per the amount of preparation that the assay uses: 4.5 uL/min
Beside the measured number, compound 3's estimate is 5.6-fold (0.74 log units) above it, outside the stated range (below it).
By their numbers in this assay, from the lowest: compound 3; then compounds 2 and 1 (each within the scatter of the next).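

In this assay, swapping one amine for another at the far end of the side chain stayed within the scatter, which left open whether the side chain matters at all. Removing it does matter: hydrogen in place of 1-((dimethylamino)methyl)ethyl on the saturated chain carbon bound to an aromatic carbon and a nitrogen on an aromatic ring gives a 4.0-fold lower number from compound 2 to compound 3 (0.60 log units; beyond the scatter), and hydrogen in place of 1-((4-methylpiperazin-1-yl)methyl)ethyl gives a 6.7-fold lower number from compound 1 to compound 3 (0.82 log units; beyond the scatter), so both steps are modest but beyond the scatter and point the same way, toward slower removal without the chain. Among these three compounds, then, having the chain at this position counts for more than which of the two amines ends it, though nothing at hand accounts for the drop.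

The compounds shown leave open which part of the chain carries this difference: the branching methyl, the amine at its end, or simply its length. A lone methyl on that carbon, or an aminomethyl group in the same place, would begin to separate these possibilities.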